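Methyl additions on the sulfonyl aryl ring: cytotoxicity notes

The source may report more compounds than this note shows. Statements on the series, on what has been measured and on what is new or still open speak of the compounds shown alone.

Measured compounds:
- compound 1, `Cc1cc(C)cc(S(=O)(=O)n2c(=O)[nH]c3ccc(Cl)cc32)c1`: in an ADME assay on MT4 cells (Homo sapiens) for cytotoxicity (on this read-out higher numbers stand for lower toxicity in this test and lower numbers for higher toxicity in this test), compound 1 gives 39000 nM.
- compound 2, `Cc1cccc(S(=O)(=O)n2c(=O)[nH]c3ccc(Cl)cc32)c1`: in this assay compound 2 gives only a limit of the assay, > 307000 nM.
- compound 3, `Cc1ccc(S(=O)(=O)n2c(=O)[nH]c3ccc(Cl)cc32)c(C)c1`: in this assay compound 3 gives 39300 nM.

All three share the same core and differ only in the methyl pattern on the six-membered aromatic ring of carbon only. Going by the values given here, the one counted change is methyl in place of hydrogen on an aromatic carbon; it gives an at least 7.8-fold lower number from compound 2 to compound 1 (0.89 log units; beyond the scatter). The size of that step is open-ended because compound 2 sits at the limit of > 307000 nM in this assay, at which 1 of the 3 values shown sits. Compound 3 and compound 1 lie within the scatter of each other, so no order between them can be read. How compound 3 differs from compound 2 is not broken down here.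

The unmeasured compound 4, `Cc1cc(C)c(S(=O)(=O)n2c(=O)[nH]c3ccc(Cl)cc32)c(C)c1`, carries methyl in place of hydrogen on an aromatic carbon. Among the compounds with values here, this is the same kind of change as the one from compound 2 to compound 1, not the same: the entering methyl there sat meta to a large group and meta to a methyl group, whereas here it sits ortho to a large group and meta to two methyl groups.

Given that compound 1 with 39000 nM and compound 3 with 39300 nM are within the scatter of each other, a further methyl is expected to move the number little, and the step of a 1.1-fold lower number from compound 3 to compound 4 (0.05 log units; within the scatter) is estimated to stay within the scatter. Compound 4 is therefore expected to give about 35000 nM, with a range from 12000 nM to 110000 nM.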

Compound 4, half-maximal cytotoxic concentration: > 356000 nM
Compound 4: no number, only a limit; the forecaster's own chance of this, stated with the estimate: 10%; middle value at least 10-fold (1.00 log units) from the limit.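

In this assay, going by these compounds, the methyl in place of hydrogen on an aromatic carbon gives an at least 9.0-fold higher number from compound 3 to compound 4 (0.95 log units; beyond the scatter), so the earlier step does not carry over to this core in direction or in size: the same change on two cores in this assay, an at least 7.8-fold lower number (0.89 log units; beyond the scatter) from compound 2 to compound 1 and an at least 9.0-fold higher number (0.95 log units; beyond the scatter) from compound 3 to compound 4, at least 71-fold (1.85 log units) apart, beyond the scatter of two such steps Compound 4 gives only a limit of the assay, > 356000 nM, and compound 2 likewise sits at a limit, so both steps are open-ended and their true sizes remain unknown. This pair of steps shows that, on these compounds, the change cannot be carried from one core to another as a fixed shift in the read-out, but it does not show why; the entering methyl sits meta to a large group and meta to a methyl group in one step and ortho to a large group and meta to two methyl groups in the other, and the core and the place of the change cannot be separated here.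

On these data alone, the numbers that lie behind the limits of compound 2 and compound 4 remain open. Also open, as far as these compounds go, is how an amine, a carboxylic acid or a longer chain in the place of the entering methyl would read in this assay.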